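Swapping the heterocycle on a sulfonamide nitrogen

This account rests on a few compounds, and the source may have more. Where it says the series, first, only, none or still open, it means among the compounds named here.

Measured compounds:
- compound 1, `Cc1noc(NS(=O)(=O)c2ccc(N/C(S)=N\c3ccnc4cc(C(F)(F)F)ccc34)cc2)c1C`: 34000 nM
- compound 2, `O=S(=O)(Nc1nccs1)c1ccc(N/C(S)=N\c2ccnc3cc(C(F)(F)F)ccc23)cc1`: 27200 nM

In a functional assay on AS49-RAW cells (Homo sapiens) for antiproliferative activity, read by sulforhodamine B assay, with a stated time of 48 h (a lower number here means a stronger inhibitor, a higher number a weaker inhibitor), compound 1 gives 34000 nM, and compound 2 gives 27200 nM. These two numbers sit within the scatter of each other, so neither compound can be called the stronger one; the only shown step, a 1.3-fold lower number from compound 1 to compound 2 (0.10 log units; within the scatter), exchanges one small aromatic ring for another on the sulfonamide nitrogen and leaves the number essentially unchanged.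

Compound 3, `O=S(=O)(Nc1ccccn1)c1ccc(N/C(S)=N\c2ccnc3cc(C(F)(F)F)ccc23)cc1`, continues at the same place: pyridin-2-yl in place of 1,3-thiazol-2-yl on a sulfonamide nitrogen. Within the data shown here, the one step that bears on this kind of change, a 1.3-fold lower number from compound 1 to compound 2 (0.10 log units; within the scatter), was within the scatter, so no move beyond the scatter is expected in this assay; the expected step is a 1.0-fold lower number from compound 2 to compound 3 (0.02 log units; within the scatter). Compound 3 is therefore estimated at 26000 nM, with a range from 10000 nM to 65000 nM.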

Compound 3, half-maximal inhibitory concentration: 33500 nM
Compound 3: middle estimate off by 1.3-fold (0.11 log units), on the low side; the range from low to high includes it.
By their numbers in this assay, from the lowest: compounds 2, 3 and 1 (each within the scatter of the next).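

Moving from a five-membered ring with 2 hetero atoms to a six-membered ring with 1 hetero atom on the sulfonamide nitrogen gives no readable difference in this assay (a 1.2-fold higher number from compound 2 to compound 3 (0.09 log units; within the scatter)). The comparison with the dimethyl-substituted ring of compound 1 reads the same (a 1.0-fold lower number from compound 1 to compound 3 (0.01 log units; within the scatter)), so all three aromatic rings now lie within the scatter of one another, and for these three, ring size and hetero atom count do not separate the compounds. No measurement shown here offers an explanation for this flat result.

All three groups are aromatic rings, so the compounds shown leave open whether this position stays as flat with a non-aromatic group, such as a simple propyl chain. They also leave open what a pyridin-2-yl ring carrying a carboxylic acid or an amine would do.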